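A Ring Replaces the Chain Tip on Compound 1

A few compounds are considered here, and "the series" means these few. Any claim that something is new, unique, unknown or untested is made for them only; others in the source may bear on it.

Going by the values given here, compound 1 `CCCCn1nc(C(=O)N[C@H]2COc3ccccc3N(C)C2=S)nc1Cc1ccccc1` gives 510 nM in a functional assay on HT-29 cells (Homo sapiens) for inhibition, read by luminescence and CellTiter-Glo, with a stated time of 24 h (a lower number here means that less compound is needed, a higher number that more compound is needed for the effect), the lowest of the two numbers known so far. Among the compounds with values here, the only comparison available is compound 2 `CN1C(=S)[C@@H](NC(=O)c2nc(Cc3ccccc3)n(CCC(F)(F)F)n2)COc2ccccc21`, which in this assay gives 1550 nM. That step, a 3.0-fold higher number from compound 1 to compound 2 (0.48 log units; beyond the scatter), altered the chain on a saturated chain carbon two bonds along from an aromatic nitrogen, and the number rose. Compound 3 `CN1C(=S)[C@@H](NC(=O)c2nc(Cc3ccccc3)n(CC3CCOCC3)n2)COc2ccccc21` changes the same chain, though closer in, by a different exchange: oxan-4-yl in place of propyl on a saturated chain carbon bound to an aromatic nitrogen. Within the data shown here, since the one measured step on this chain raised the number, and the present exchange is a larger one, adding a ring and a hydrogen-bond acceptor, a modest rise beyond the scatter is expected, roughly a 1.8-fold higher number from compound 1 to compound 3 (0.25 log units; within the scatter), though a single precedent leaves the direction uncertain. Compound 3 is therefore estimated at 900 nM, with a likely range from 300 nM to 2700 nM.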

Compound 3, half-maximal effective concentration: 6310 nM
The estimate for compound 3 lay 7.0-fold (0.85 log units) below the measured number; measured number outside the range, above it.
By their numbers in this assay, from the lowest: compound 1; then compound 2; then compound 3.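

Oxan-4-yl in place of propyl on a saturated chain carbon bound to an aromatic nitrogen gives in this assay a 12-fold higher number from compound 1 to compound 3 (1.09 log units; beyond the scatter) and so shows that this place responds strongly to a change of group. The same ring in place of 2,2,2-trifluoroethyl gives a 4.1-fold higher number from compound 2 to compound 3 (0.61 log units; beyond the scatter) as well, so the ring-bearing chain stands apart from both earlier chains, and among the three compounds the butyl chain of compound 1 keeps the lowest number. Why the ring raises the number cannot be told from these data.

The compounds shown leave open whether the rise goes with the ring itself or with its oxygen, a question that a cyclohexylmethyl chain, with carbon in place of that oxygen, would separate. They also leave open how a longer unbranched chain such as pentyl would behave at this place.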